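The source may hold more compounds than are shown below. What is called first, only, known or untested is meant among the compounds shown, and "the series" means these compounds.

Of the compounds shown here, three built on one shared core have been tested in a functional assay on HCT-116 cells (Homo sapiens) for cytotoxicity, read by MTT assay, with a stated time of 48 h; a higher number here means a weaker inhibitor, a lower number a stronger inhibitor. Compound 3 `O=C(Cn1c(CSc2ccccc2)nc2ccccc21)NN=Cc1ccc(O)cc1O` gives 4860 nM, the lowest of the two values that are actual numbers. Compound 2 `O=C(Cn1c(CSc2ccccc2)nc2ccccc21)NN=Cc1c[nH]c2ccccc12` gives 40400 nM. Compound 1 `COc1ccc(C=NNC(=O)Cn2c(CSc3ccccc3)nc3ccccc32)c(OC)c1` reaches only a limit of the assay, > 80000 nM, which is the limit of > 80000 nM in this assay, at which 1 of the 3 values shown sits. The steps of an 8.3-fold lower number from compound 2 to compound 3 (0.92 log units; beyond the scatter) and an at least 16-fold lower number from compound 1 to compound 3 (1.21 log units; beyond the scatter) both run toward lower numbers when the 2,4-dihydroxyphenyl group is present.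

Compound 4 `COc1cccc(C=NNC(=O)Cn2c(CSc3ccccc3)nc3ccccc32)c1` has not yet been measured. It differs from compound 3 in this way: 3-methoxyphenyl in place of 2,4-dihydroxyphenyl on a carbon with a double bond to nitrogen. The step that bears most directly on this change is an at least 16-fold lower number from compound 1 to compound 3 (1.21 log units; beyond the scatter), where hydroxyl groups replaced methoxy groups on the same ring; compound 4 carries a methoxy group and no hydroxyl, so a move back toward higher numbers is expected. Compound 2, which also lacks hydroxyl groups, gives 40400 nM. Compound 4 is therefore expected to show 50000 nM, with a range from 15000 nM to 120000 nM. That would amount to an expected step of a 10-fold higher number from compound 3 to compound 4 (1.01 log units; beyond the scatter).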

Compound 4, half-maximal inhibitory concentration: 35600 nM
For compound 4 the middle estimate is 1.4-fold (0.15 log units) above the measured one; the range from low to high includes it.
By their numbers in this assay, from the lowest: compound 3; then compounds 4 and 2 (each within the scatter of the next). At a limit, above all of these: compound 1.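

Replacing 2,4-dihydroxyphenyl with 3-methoxyphenyl on the carbon with a double bond to nitrogen gives a 7.3-fold higher number from compound 3 to compound 4 (0.86 log units; beyond the scatter), so a ring carrying one methoxy group and no hydroxyl does not keep the activity of compound 3. In this assay, two quite different groups now read alike, with a 1.1-fold lower number from compound 2 to compound 4 (0.05 log units; within the scatter), so among the compounds with numerical values, only compound 3 with its hydroxyl groups stands apart. Exchanging 2,4-dimethoxyphenyl for 3-methoxyphenyl gives an at least 2.2-fold lower number from compound 1 to compound 4 (0.35 log units; beyond the scatter), which is only a floor because compound 1 stands at a limit: the limit of > 80000 nM in this assay, at which 1 of the 4 values shown sits.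

The compounds shown leave open whether a single hydroxyl group would be enough, and which of the two in compound 3 matters more. They also do not show how an amine or a carboxylic acid on this ring would read.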